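From Aryl Ester to Isobutyl Ether at the Oxygen

The source may report more compounds than this note shows. Statements on the series, on what has been measured and on what is new or still open speak of the compounds shown alone.

Compound 3 `Cc1nn(-c2ncnc3nc[nH]c23)c2c1C(OC(=O)c1ccc(F)cc1)CC(=O)N2` gives 4 nM in a functional assay on HEK293 cells for agonist activity at G-protein coupled receptor 39 (Homo sapiens), read by scintillation proximity assay and inositol phosphate accumulation, with a stated time of 75 min, in the presence of a further agent that is not named here (on this read-out higher numbers stand for an effect only at larger amounts of compound and lower numbers for an effect already at smaller amounts), and stands second highest of the three numbers measured: compound 1 `Cc1nn(-c2ncnc3nc[nH]c23)c2c1C(OCC(=O)c1ccc(F)cc1)CC(=O)N2` gives 3 nM and compound 2 `Cc1nn(-c2ncnc3nc[nH]c23)c2c1C(c1ccc(OC(C)C)cc1)CC(=O)N2` gives 18 nM. The step of a 1.3-fold higher number from compound 1 to compound 3 (0.12 log units; within the scatter) lies within the scatter, while the step of a 4.5-fold lower number from compound 2 to compound 3 (0.65 log units; beyond the scatter) goes beyond it. Compound 4 `Cc1nn(-c2ncnc3nc[nH]c23)c2c1C(OCC(C)C)CC(=O)N2` has not been measured; it differs from compound 3 by isobutyl in place of (4-fluorophenyl)carbonyl on an oxygen on a saturated carbon. Within the data shown here, neither measured step removes an aromatic ring altogether, so no step bears closely on this change, and compound 4 is expected to show a modest rise, a 7.5-fold higher number from compound 3 to compound 4 (0.88 log units; beyond the scatter). Compound 4 is estimated at 30 nM, with a range from 5 nM to 200 nM.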

Compound 4, half-maximal effective concentration: 4 nM
Compound 4: middle estimate off by 7.5-fold (0.88 log units), on the high side, and the stated range ends above it.
By their numbers in this assay, from the lowest: compounds 1, 3 and 4 (each within the scatter of the next); then compound 2.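

In this assay, isobutyl, which has no ring, serves on this oxygen as well as (4-fluorophenyl)carbonyl, with no change at the digits printed from compound 3 to compound 4 (within the scatter) and with a 1.3-fold higher number from compound 1 to compound 4 (0.12 log units; within the scatter) as well. On the saturated ring carbon, the isobutoxy group also gives a 4.5-fold lower number from compound 2 to compound 4 (0.65 log units; beyond the scatter) against the 4-isopropoxyphenyl group, so neither an aromatic ring nor a carbonyl is needed here among these compounds. Nothing available explains this result.

Still open, from the compounds shown here alone, is how a methyl group, a longer chain, an amine or a carboxylic acid on this oxygen would read.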